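Trimming the Butyl Chain of Compound 3 to Methyl

The source may hold more compounds than are shown below. What is called first, only, known or untested is meant among the compounds shown, and "the series" means these compounds.

In a functional assay (aorta) with Rattus norvegicus as the target (a lower number here means a stronger inhibitor, a higher number a weaker inhibitor), compound 3 (`CCCCc1cn2ccccc2c1S(=O)(=O)c1ccc(OCCCN(CCCC)CCCC)cc1`) gives 284 nM. That value lies within the scatter of compound 2 (`CCCCc1cn2ccccc2c1S(=O)(=O)c1ccc(OCCCN(CCC)CCC)cc1`), which gives 570 nM. Compound 1 (`CCCCN(CCCC)CCCCOc1ccc(S(=O)(=O)c2c(C(C)C)cn3ccccc23)cc1`) gives 20.2 nM, a clearly lower number than compound 3.

Compound 4 (`CCCCN(CCCC)CCCOc1ccc(S(=O)(=O)c2c(C)cn3ccccc23)cc1`) differs from compound 3 by hydrogen in place of propyl on a saturated chain carbon bound to an aromatic carbon, so that butyl becomes methyl.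

Among the compounds with values here, only one single-place step has been measured, a 2.0-fold lower number from compound 2 to compound 3 (0.30 log units; within the scatter), with dibutylamino in place of dipropylamino. It lies within the scatter, and it concerns a different place on the molecule, so it gives no size for this change. Within the data shown here, no measured pair isolates the butyl group, so no direction can be argued and the uncertainty is wide. The best expectation therefore stays close to compound 3 at 284 nM.

The expected change is a 1.1-fold higher number from compound 3 to compound 4 (0.02 log units; within the scatter), with no shift beyond the scatter anticipated. For compound 4 the estimated value is 300 nM, with an expected range from 80 nM to 1100 nM.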

Compound 4, half-maximal inhibitory concentration: 162 nM
Compound 4: middle estimate off by 1.9-fold (0.27 log units), on the high side, and the stated range covers the measured number.
By their numbers in this assay, from the lowest: compound 1; then compounds 4, 3 and 2 (each within the scatter of the next, the first and the last beyond it).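

Within the data shown here, this is the first step measured at this position: in this assay, butyl to methyl gives a 1.8-fold lower number from compound 3 to compound 4 (0.24 log units; within the scatter), which stays within the scatter. Removing a propyl, 3 heavy atoms, from a saturated chain carbon bound to an aromatic carbon therefore leaves the number about where it was, so in this assay compound 3 does not depend on its full butyl chain to hold this level of activity. Nothing measured here gives a reason for this result.

Compound 1 differs from compound 4 in more than one place, so its value cannot be tied to the group at this position alone. Also open, on these data alone, is how this position would respond to a group of a different kind, such as a carboxylic acid or a phenyl ring, in place of methyl.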